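The source may hold more compounds than are shown below. What is called first, only, known or untested is meant among the compounds shown, and "the series" means these compounds.

In a functional assay on MIA PaCa-2 cells (Homo sapiens) for inhibition, read by MTT assay, with a stated time of 48 h, tested at 10 uM (on this read-out lower numbers stand for less inhibition of growth and higher numbers for more inhibition of growth at the one concentration tested), compound 3 `O=C(/C=C/c1ccc(OCc2cn(Cc3ccccc3)nn2)cc1)c1ccc(Br)cc1` stands with the highest of the three numbers at 44%, although its gap to each of the other two lies within the scatter. The nearest value belongs to compound 2 `C#CCOc1ccc(/C=C/C(=O)c2ccc([N+](=O)[O-])cc2)cc1`, which in this assay gives 42%, and the furthest to compound 1 `C#CCOc1ccc(/C=C/C(=O)c2ccc(Br)cc2)cc1`, which gives 34%. Going by the values given here, the only step between measured compounds that differ in one place, nitro in place of bromo on an aromatic carbon, runs a number 8 percentage points higher from compound 1 to compound 2 (within the scatter).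

Compound 4 `O=C(/C=C/c1ccc(OCc2cn(Cc3ccc(Br)cc3)nn2)cc1)c1ccc(Br)cc1` differs from compound 3 in one place: bromo in place of hydrogen on an aromatic carbon, the position being on an aromatic carbon of a six-membered aromatic ring of carbon only, para to a large group. Among the compounds with values here, none of the measured steps concerns this change; the step from compound 1 to compound 2 touches a different ring and a different exchange, and was itself within the scatter. Within the data shown here, with no measured step bearing on the exchange, the expectation for compound 4 can rest only on its closeness to compound 3, and the step is therefore expected to be no change at the digits printed from compound 3 to compound 4 (within the scatter), nothing beyond the scatter. Compound 4 is thus estimated to give about 44% in this assay, within a range from 30% to 58%.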

Compound 4, percent growth inhibition at one concentration: 29%
Beside the measured number, compound 4's estimate is 15 percentage points above it, outside the stated range (below it).
By their numbers in this assay, from the lowest: compounds 4, 1, 2 and 3 (each within the scatter of the next, the first and the last beyond it).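

In this assay, going by these compounds alone, bromo in place of hydrogen on the benzyl group, on an aromatic carbon of a six-membered aromatic ring of carbon only and para to a large group, gives the one step in this set that lies beyond the scatter: a number 15 percentage points lower from compound 3 to compound 4 (beyond the scatter). Within the data shown here, this position is therefore not indifferent to substitution, since phenyl to 4-bromophenyl at the far end of the molecule, a change of a single heavy atom, is enough to move the number, whereas the only earlier step, a number 8 percentage points higher from compound 1 to compound 2 (within the scatter), concerned a different ring and a different exchange and stayed within the scatter. Nothing available accounts for the lower number of compound 4, so the result stands as an observation without an explanation.

The compounds shown leave open whether another group on this same carbon, such as fluoro, methoxy, an amine or a carboxylic acid, would lower the number as bromo does, or whether bromo on another carbon of that ring would do the same. Also open, from the compounds shown here alone, is whether the step would hold with nitro in place of the other bromo of compound 4.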